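The source may hold more compounds than are shown below. What is called first, only, known or untested is meant among the compounds shown, and "the series" means these compounds.

Measured in a functional assay on MIA PaCa-2 cells (Homo sapiens) for antiproliferative activity, read by sulforhodamine B assay, with a stated time of 48 h; on this read-out higher numbers stand for weaker inhibition and lower numbers for stronger inhibition:
- compound 1 `COc1ccc(C(=O)/C=C\Nc2ccc(-c3nc4cc(OC)c(OC)c(OC)c4s3)cc2C)cc1F`: 1800 nM
- compound 2 `COc1cc(OC)c2sc(-c3ccc(N/C=C\C(=O)c4ccc(OC)c(F)c4)c(C)c3)nc2c1`: 16300 nM
- compound 3 `COc1ccc(C(=O)/C=C\Nc2ccc(-c3nc4cc(OC)c(OC)c(OC)c4s3)cc2)cc1F`: 19400 nM

Of these three, compound 1 gives the lowest number, and so the strongest inhibition. Both steps away from it raise the number by more than the scatter. Hydrogen in place of methoxy on an aromatic carbon gives a 9.1-fold higher number from compound 1 to compound 2 (0.96 log units; beyond the scatter), and hydrogen in place of methyl on an aromatic carbon gives an 11-fold higher number from compound 1 to compound 3 (1.03 log units; beyond the scatter).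

The next compound, not yet measured, is compound 4 `COc1cc(C(=O)/C=C\Nc2ccc(-c3nc4cc(OC)c(OC)c(OC)c4s3)cc2C)cc(OC)c1OC`. Its change is 3,4,5-trimethoxyphenyl in place of 3-fluoro-4-methoxyphenyl on a carbonyl carbon. Neither measured step alters the group on the carbonyl carbon, so neither shows directly how this swap will behave. For the measured compounds named here, they show only that one small change to compound 1 can move the number a long way, as in an 11-fold higher number from compound 1 to compound 3 (1.03 log units; beyond the scatter). The data therefore give no firm direction, and the best expectation is no shift beyond the scatter, with more room upward than downward. The expected size of the change is a 1.4-fold higher number from compound 1 to compound 4 (0.14 log units; within the scatter). For compound 4 the estimated value is 2500 nM, with an expected range from 500 nM to 12000 nM.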

Compound 4, half-maximal inhibitory concentration: 22800 nM
Compound 4: the middle estimate sits 9.1-fold (0.96 log units) below what was measured, and the stated range ends below it.
By their numbers in this assay, from the lowest: compound 1; then compounds 2, 3 and 4 (each within the scatter of the next).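

In this assay, the swap on the carbonyl carbon gives a 13-fold higher number from compound 1 to compound 4 (1.10 log units; beyond the scatter), a step beyond the scatter. For the compounds shown here, both earlier steps left this group untouched, so this is the first sign that the number also responds to a change here, with the rest of compound 1 kept as it is. The swap is not a single small edit, however: the entering 3,4,5-trimethoxyphenyl group loses the fluorine and gains methoxy groups, and nothing available accounts for the weaker inhibition of compound 4.

The compounds shown leave open which part of the swap matters, the lost fluorine or the added methoxy groups, and a plain phenyl group on the carbonyl carbon would help to tell these apart. They also leave open whether this position accepts any group that gives inhibition as strong as that of compound 1 or stronger, for example a pyridine ring in place of the phenyl ring.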